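This account rests on a few compounds, and the source may have more. Where it says the series, first, only, none or still open, it means among the compounds named here.

Measured compounds:
compound 1, `CC(C)=CCC1Cc2c(O)cc(=O)n(CCCO)c2CC1(C)C`, 25.6%;
compound 2, `CC(C)=CCC1Cc2c(OCc3ccccc3)cc(=O)n(CCCO)c2CC1(C)C`, -0.3%;
compound 3, `CC(C)=CCC1Cc2c(OCCCNS(=O)(=O)c3ccc(Br)cc3)cc(=O)n(CCCO)c2CC1(C)C`, 19.5%.

All three were tested in a functional assay on PANC-1 cells (Homo sapiens) for inhibition, read by MTT assay, with a stated time of 24 h, tested at 10 uM; a higher number here means more inhibition at the concentration tested (going by the name of the read-out), a lower number less inhibition. Compound 3 stands with compound 1: the two values cannot be told apart, while both lie beyond the scatter from compound 2, which shows essentially no effect. For the measured compounds named here, the only step between compounds differing in one place is a number 25.9 percentage points lower from compound 1 to compound 2 (beyond the scatter), a change on an oxygen of the aromatic ring rather than on the chain nitrogen.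

Compound 4, `CC(C)=CCC1Cc2c(OCCCNC(=O)c3ccco3)cc(=O)n(CCCO)c2CC1(C)C`, differs from compound 3 by (furan-2-yl)carbonyl in place of (4-bromophenyl)sulfonyl on an amine nitrogen. Going by the values given here, no measured step touches this position; the one step known concerns a different place, so it does not bear on the change. The group that leaves and the group that enters carry no donors and the same count of acceptors. With nothing pointing either way, no step beyond the scatter is expected, a number 3.5 percentage points lower from compound 3 to compound 4 (within the scatter). Compound 4 is therefore estimated at 16%, within 0% to 32%.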

Compound 4, a percentage reported as inhibition, at one concentration (the size of the read-out at that concentration, not a potency): 2.1%
Compound 4: middle estimate off by 13.9 percentage points, on the high side; the range from low to high includes it.
By their numbers in this assay, from the lowest: compounds 2 and 4 (each within the scatter of the next); then compounds 3 and 1 (each within the scatter of the next).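

In this assay, for the compounds shown here, the group on the amine nitrogen proves not to be a neutral choice: (furan-2-yl)carbonyl in place of (4-bromophenyl)sulfonyl gives a number 17.4 percentage points lower from compound 3 to compound 4 (beyond the scatter) at a position no earlier step had touched. A chain on the ring oxygen therefore does not by itself hold the read-out, as the chain ending in the furan amide gives a number 23.5 percentage points lower from compound 1 to compound 4 (beyond the scatter) and then stands level with the benzyl ether, with a number 2.4 percentage points higher from compound 2 to compound 4 (within the scatter) in the same comparison. Nothing available explains this drop.

The compounds shown do not separate the sulfonyl link from the ring it carries, so a 4-bromobenzoyl or a plain phenylsulfonyl group on this nitrogen would be the telling comparison. From the compounds shown here alone, whether a free amine at the end of this chain would behave like either group also remains open.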